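This account rests on a few compounds, and the source may have more. Where it says the series, first, only, none or still open, it means among the compounds named here.

In an ADME assay on WI-38 cells (Homo sapiens) for cytotoxicity, read by MTT assay, with a stated time of 72 h (a higher number here means a weaker inhibitor, a lower number a stronger inhibitor), compound 1 `O=C(CCc1cccc2c1B(O)OC2)Nc1ccccc1` gives 30000 nM. Compound 2 `COc1ccccc1NC(=O)CCc1cccc2c1B(O)OC2` carries one extra group, (methoxy in place of hydrogen on an aromatic carbon), and gives 1600 nM; that single change made the step of a 19-fold lower number from compound 1 to compound 2 (1.27 log units; beyond the scatter). Compound 3 `COc1cccc(-c2cccc(NC(=O)CCc3ccc4c(c3)COB4O)c2)c1` has a core whose difference from the core of compound 1 is not broken down here. For compound 3 the result is only a limit of the assay, > 100000 nM, in keeping with the limit of > 100000 nM in this assay, at which 1 of the 3 values shown sits. Compound 4 `COc1cc(OC)cc(-c2cccc(NC(=O)CCc3ccc4c(c3)COB4O)c2)c1` is not yet measured and differs from compound 3 by methoxy in place of hydrogen on an aromatic carbon. This is the same kind of change as between compound 1 and compound 2, but the place differs: there the methoxy sat ortho to a large group, here it sits meta to a large group and meta to a methoxy group. Resting on compound 3 standing at a limit > 100000 nM, the expected step is an at least 1.1-fold lower number from compound 3 to compound 4 (0.04 log units; that floor lies within the scatter). Compound 4 is estimated at 90000 nM, between 30000 nM and 200000 nM.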

Compound 4, half-maximal inhibitory concentration: > 100000 nM
Compound 4 ended at the assay's limit; the forecaster's own chance of this, stated with the estimate: 55%; middle value at least 1.1-fold (0.04 log units) away from the limit.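

In this assay, for the compounds shown here, compound 3 and compound 4 both stand at a limit, so no step between them can be read: the limit of > 100000 nM in this assay, at which 2 of the 4 values shown sit. The compounds shown leave open whether the added methoxy on compound 4 changes the result at all.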